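This account rests on a few compounds, and the source may have more. Where it says the series, first, only, none or still open, it means among the compounds named here.

Working notes on the series. In a functional assay on A549 cells (Homo sapiens) for inhibition, read by MTT assay (on this read-out higher numbers stand for weaker inhibition and lower numbers for stronger inhibition), compound 1 `CCCCCCCCn1cc(/C=C/C(=O)c2ccc(NC(=O)CN3CCN(c4ccccc4F)CC3)cc2)nn1` gives 47100 nM. Compound 2 `O=C(CN1CCC(Cc2ccccc2)CC1)Nc1ccc(C(=O)/C=C/c2cn(Cc3ccc(Br)cc3)nn2)cc1` gives 40000 nM in this assay, and compound 3 `CCCCCCCCn1cc(/C=C/C(=O)c2ccc(NC(=O)CN3CCC(Cc4ccccc4)CC3)cc2)nn1` gives 43800 nM. The three numbers lie within the usual scatter of one another, so compound 1 cannot be set apart from compound 2 or compound 3 on these readings; the whole set so far sits in one narrow band. Going by the values given here, the single one-point step measured to date, a 1.1-fold higher number from compound 2 to compound 3 (0.04 log units; within the scatter), concerns the group on a saturated chain carbon bound to an aromatic nitrogen, a part of the molecule remote from the change now in question, and it is flat.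

Compound 4 `CCCCCCCCn1cc(/C=C/C(=O)c2ccc(NC(=O)CN3CCN(c4ccccc4)CC3)cc2)nn1` differs from compound 1 by hydrogen in place of fluoro on an aromatic carbon. Among the compounds with values here, no measured step touches this position, and the data hold nothing that points to a shift in either direction. For compound 4 the expected step is a 1.0-fold lower number from compound 1 to compound 4 (0.02 log units; within the scatter), nothing beyond the scatter. Compound 4 is estimated at 45000 nM in this assay, with a range from 22000 nM to 90000 nM.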

Compound 4, half-maximal inhibitory concentration: 52400 nM
The estimate for compound 4 lay 1.2-fold (0.07 log units) below the measured number, and the stated range covers the measured number.
By their numbers in this assay, from the lowest: compounds 2, 3, 1 and 4 (each within the scatter of the next).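

Going from 2-fluorophenyl to phenyl gives, in this assay, a 1.1-fold higher number from compound 1 to compound 4 (0.05 log units; within the scatter), so this is the first measured step at this aromatic carbon, ortho to a large group, and fluoro and hydrogen cannot be told apart there on this read-out. With this single pair, the position shows no sensitivity to this one exchange, and compound 4 stays in the same narrow band as the other compounds of the series. No supporting measurement bears on this result.

Open, going by these compounds, is whether a different group on this aromatic carbon, such as methoxy, an amine or a carboxylic acid, would give a step beyond the scatter. Also open, on these data alone, is whether the exchange of fluoro for hydrogen stays as flat with the 4-bromophenyl group of compound 2 on the aromatic nitrogen side.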